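This account rests on a few compounds, and the source may have more. Where it says the series, first, only, none or still open, it means among the compounds named here.

Measured compounds:
compound 1 `CC(C)(C)C(=O)N(CCCCCCN1C[C@H](O)[C@@H](O)[C@H](O)[C@H]1CO)c1cc(F)ccc1F` with > 500000 nM
compound 2 `CC(C)(C)C(=O)N(CCCCCCN1C[C@H](O)[C@@H](O)[C@H](O)[C@H]1CO)C1CC1` with "not determined" (no result reported)
compound 3 `CC(C)(C)C(=O)N(CCCCCCN1C[C@H](O)[C@@H](O)[C@H](O)[C@H]1CO)C1CCCC1` with > 500000 nM

In an ADME assay on Huh-7 cells (Homo sapiens) for cytotoxicity, read by MTT assay (on this read-out higher numbers stand for lower toxicity in this test and lower numbers for higher toxicity in this test), compound 3 gives > 500000 nM, which is a limit of the assay and not a number. Compound 1 likewise reaches only a limit, > 500000 nM, in this assay. For compound 2 this assay reports "not determined" (no result reported). Compound 3 therefore stands at the limit of > 500000 nM in this assay, at which 2 of the 3 values shown sit, with no single number of its own.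

Compound 4 `CC(C)(C)C(=O)N(CCCCCCN1C[C@H](O)[C@@H](O)[C@H](O)[C@H]1CO)C1CCCCCCC1` differs from compound 3 by cyclooctyl in place of cyclopentyl on an amide-type nitrogen. Among the compounds with values here, the only measured step that touches this position, from compound 1 to compound 3, is a step that the two limits leave unreadable from compound 1 to compound 3, so it gives no readable size. Within the data shown here, nothing among the measured compounds bears on the exchange of one carbon ring for another on this nitrogen. The size of the step in this assay is therefore unknown, and compound 4 is expected to sit at the same limit as compound 3.

Compound 4 is estimated at 600000 nM in this assay, with a range from 200000 nM to 2000000 nM. The expected step from compound 3 to compound 4 is a step that the limit leaves unreadable from compound 3 to compound 4.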

Compound 4, half-maximal cytotoxic concentration: 150000 nM
Estimate against measurement, compound 4: 4.0-fold (0.60 log units) above; the measured number lies below the stated range.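

In this assay, the substituent on the amide-type nitrogen now proves able to move the read-out: cyclooctyl in place of cyclopentyl gives an at least 3.3-fold lower number from compound 3 to compound 4 (0.52 log units; beyond the scatter), and cyclooctyl in place of 2,5-difluorophenyl gives an at least 3.3-fold lower number from compound 1 to compound 4 (0.52 log units; beyond the scatter). Both steps lie beyond the usual scatter, so a change of carbon ring at this position is not silent in this test, as the unreadable step from compound 1 to compound 3 had left possible. Compound 4 is also the only compound shown with a number of its own, while the others with a result stop at a limit of the assay: the limit of > 500000 nM in this assay, at which 2 of the 4 values shown sit.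

From the compounds shown here alone, whether the change in the read-out follows ring size remains open, since compound 2, with its cyclopropyl group, has no reported result. Going by these compounds, how cyclohexyl, cycloheptyl or a straight octyl chain would read on this nitrogen also remains open.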